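The compounds below may be only part of what the source reports. "The series", "measured", "known", "first", "only" and "open" are said of these compounds alone.

Compound 1, `c1ccc(COc2ccc(Nc3ncnc4cc5c(cc34)OCCOCCOCCO5)cc2)cc1`, is the anchor of this small set: in a functional assay on SH-SY5Y cells (Homo sapiens) for antiproliferative activity, read by MTT assay, with a stated time of 72 h (on this read-out lower numbers stand for stronger inhibition and higher numbers for weaker inhibition), compound 1 gives 23900 nM. Compound 2, `FC(F)(F)c1ccc(COc2ccc(Nc3ncnc4cc5c(cc34)OCCOCCOCCO5)cc2)cc1`, carries trifluoromethyl in place of hydrogen on an aromatic carbon. In this assay compound 2 reaches only the limit, > 100000 nM. The step that this change made is an at least 4.1-fold higher number from compound 1 to compound 2 (0.62 log units; beyond the scatter), a value that stands at the limit of > 100000 nM in this assay, at which 1 of the 3 values shown sits.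

Compound 3, `c1ccc(COc2ccc(Nc3ncnc4cc5c(cc34)OCCOCCO5)cc2)cc1`, has a core whose difference from the core of compound 1 is not broken down here; in this assay compound 3 gives 39300 nM. Compound 4, `FC(F)(F)c1ccc(COc2ccc(Nc3ncnc4cc5c(cc34)OCCOCCO5)cc2)cc1`, has not yet been measured and differs from compound 3 by trifluoromethyl in place of hydrogen on an aromatic carbon, the same change seen before. Beside the earlier step, the step from compound 3 to compound 4 is expected to be a 4.1-fold higher number from compound 3 to compound 4 (0.61 log units; beyond the scatter), because an at least 4.1-fold higher number from compound 1 to compound 2 (0.62 log units; beyond the scatter) was made by the same change. Compound 4 is therefore expected to give about 160000 nM, between 50000 nM and 500000 nM.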

Compound 4, half-maximal inhibitory concentration: 30400 nM
Beside the measured number, compound 4's estimate is 5.3-fold (0.72 log units) above it; the whole stated range lies above it.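

In this assay, trifluoromethyl in place of hydrogen on an aromatic carbon gives a 1.3-fold lower number from compound 3 to compound 4 (0.11 log units; within the scatter), so the change did not carry over from the core of compound 1 to the core of compound 3: the same change on two cores in this assay, an at least 4.1-fold higher number (0.62 log units; beyond the scatter) from compound 1 to compound 2 and a 1.3-fold lower number (0.11 log units; within the scatter) from compound 3 to compound 4, at least 5.4-fold (0.73 log units) apart, beyond the scatter of two such steps The value of compound 2, > 100000 nM, is a limit of the assay and not a number. These two pairs show that the result of this change depends on the core in this series, but they do not show what lies behind the difference or how the change would behave on any other core.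

On these data alone, it remains open whether a chlorine atom or a methoxy group at the same place would also differ between the two cores. As far as these compounds go, it also remains open how trifluoromethyl would read on a core with a longer chain.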